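A few compounds are considered here, and "the series" means these few. Any claim that something is new, unique, unknown or untested is made for them only; others in the source may bear on it.

In an ADME assay on microsomes from liver (Homo sapiens) for metabolic stability, with a stated time of 10 min (on this read-out lower numbers stand for a less stable compound and higher numbers for a more stable compound), compound 1 `CC(C)S(=O)(=O)NC(=O)c1ccc(Nc2nc(NC3(c4ccc(Cl)cc4)CC3)nc(OCC(F)(F)F)n2)cc1` gives 100%. Compound 2 `O=C(NS(=O)(=O)c1ccccc1)c1ccc(Nc2nc(NC3(c4ccc(Cl)cc4)CC3)nc(OCC(F)(F)F)n2)cc1` differs from it only on the sulfonyl sulfur, where phenyl stands in place of isopropyl, and in this assay compound 2 gives 100%. The step of no change at the digits printed from compound 1 to compound 2 (within the scatter) thus shows no change beyond the scatter, so compound 2 stands level with compound 1 at the digits shown, and nearest to it. Compound 3 `COC(=O)NCCS(=O)(=O)NC(=O)c1ccc(Nc2nc(NC3(c4ccc(Cl)cc4)CC3)nc(OCC(F)(F)F)n2)cc1` has not yet been measured. It differs from compound 2 in one place: 2-((methoxycarbonyl)amino)ethyl in place of phenyl on a sulfonyl sulfur. Going by the values given here, the only measured step that bears on this change is the earlier exchange on the same sulfonyl sulfur, and that step was flat; nothing among the measured compounds points to a direction for a further exchange at that position. Compound 3 is therefore expected to remain within the scatter of compound 2, a step of a number 4 percentage points lower from compound 2 to compound 3 (within the scatter). Compound 3 is estimated at 96%, with a range from 82% to 100%.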

Compound 3, percent of the compound remaining: 90%
Compound 3: middle estimate off by 6 percentage points, on the high side, within the range that was stated.
By their numbers in this assay, from the lowest: compounds 3, 1 and 2 (each within the scatter of the next).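

In this assay the sulfonyl sulfur also accepts a group of a different kind: with 2-((methoxycarbonyl)amino)ethyl, an open chain with no ring that carries nitrogen and oxygen, the read-out shows a number 10 percentage points lower from compound 2 to compound 3 (within the scatter) and a number 10 percentage points lower from compound 1 to compound 3 (within the scatter) at this position. Going by these compounds alone, the earlier pair had exchanged only one carbon-only group for another, so this is the first sign that a chain with a hydrogen-bond donor and hydrogen-bond acceptors on this sulfur leaves the read-out within the scatter. No measurement at hand explains the behaviour of this position. On these data alone, whether an amine, a carboxylic acid or a longer chain on the same sulfur would also stay within the scatter remains open. Only this position varies among the compounds shown, and what a change elsewhere on the shared core would do is equally open.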